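The compounds below may be only part of what the source reports. "The series", "measured", "known", "first", "only" and "open" are said of these compounds alone.

In a functional assay on MCF7 cells (Homo sapiens) for antiproliferative activity, with a stated time of 48 h (a higher number here means a weaker inhibitor, a lower number a stronger inhibitor), compound 3 (`Cc1cc(=O)c2c(O)cc(OC[C@@H]3CO3)cc2o1`) gives 36200 nM, the middle of three values. Compound 1 (`Cc1cc(=O)c2c(OCC3CO3)cc(OCC3CO3)cc2o1`) gives the lower 6500 nM and compound 2 (`Cc1cc(=O)c2c(OC[C@H]3CO3)cc(OC[C@H]3CO3)cc2o1`) the higher 220000 nM. Compound 4 (`Cc1cc(=O)c2c(OC[C@@H]3CO3)cc(OC[C@@H]3CO3)cc2o1`) differs from compound 3 by (oxiran-2-yl)methyl in place of hydrogen on an oxygen on an aromatic ring. Its two stereocentres are drawn opposite to those of compound 2. Going by the values given here, the only measured step, a 34-fold higher number from compound 1 to compound 2 (1.53 log units; beyond the scatter), is large and is tied to the fact that one of compounds 1 and 2 is drawn with a defined configuration and the other without, at the place where they differ. Compound 4 is therefore expected to sit near compound 1 at 6500 nM, not near compound 2. The expected step, a clear drop in this assay, is a 9.1-fold lower number from compound 3 to compound 4 (0.96 log units; beyond the scatter). For compound 4 the estimate is 4000 nM, with an expected range of 1000 nM to 20000 nM.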

Compound 4, half-maximal inhibitory concentration: 46100 nM
For compound 4 the middle estimate is 12-fold (1.06 log units) below the measured one; measured number above the stated range.
By their numbers in this assay, from the lowest: compound 1; then compounds 3 and 4 (each within the scatter of the next); then compound 2.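

In this assay, (oxiran-2-yl)methyl in place of hydrogen on an oxygen on an aromatic ring leaves the number within the scatter, with a 1.3-fold higher number from compound 3 to compound 4 (0.10 log units; within the scatter). Going by these compounds alone, the mirror-image pair gives the first step that isolates configuration, with a 4.8-fold lower number from compound 2 to compound 4 (0.68 log units; beyond the scatter): the fact that compounds 2 and 4 differ only in the configuration as drawn. The form drawn without configuration keeps the lowest number, with a 7.1-fold higher number from compound 1 to compound 4 (0.85 log units; beyond the scatter): the fact that one of compounds 1 and 4 is drawn with a defined configuration and the other without, at the place where they differ.

From the compounds shown here alone, the composition of the material drawn without configuration stays open. Also open, going by these compounds, is whether an amine or a longer chain in place of (oxiran-2-yl)methyl on that oxygen would shift the number.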